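Tetrahydroquinoline series: aryl swap at the fused ring

A few compounds are considered here, and "the series" means these few. Any claim that something is new, unique, unknown or untested is made for them only; others in the source may bear on it.

Measured so far:
compound 1 `N#Cc1ccc(N2CCc3cc(-c4cncnc4)ccc32)cc1C(F)(F)F`: "not determined" (no result reported)
compound 2 `N#Cc1ccc(N2CCCc3c(-c4ccncc4)cccc32)cc1C(F)(F)F`: 28700 nM
compound 3 `CCN(c1ccc(C#N)c(Cl)c1)c1cc(-c2ccncc2)ccc1C`: 3580 nM

In a functional assay on PC-3 cells (Homo sapiens) for antiproliferative activity, read by CCK-8 assay, with a stated time of 6 days (on this read-out higher numbers stand for weaker inhibition and lower numbers for stronger inhibition), compound 2 gives 28700 nM, the highest of the two numbers available, and compound 3 gives 3580 nM, a gap beyond the scatter. Compound 1 has no result in this assay.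

Compound 4 `Cn1nccc1-c1cccc2c1CCCN2c1ccc(C#N)c(C(F)(F)F)c1` is the next entry, and it differs from compound 2 in one place: 1-methyl-1H-pyrazol-5-yl in place of pyridin-4-yl on an aromatic carbon. Among the measured compounds shown here, no matched pair in the measured set shows this exchange, so the direction is open. The step from compound 2 is expected to be small, of either sign, and probably within or near the scatter, as a 1.3-fold lower number from compound 2 to compound 4 (0.12 log units; within the scatter). Compound 4 is therefore estimated at 22000 nM, with a range from 6000 nM to 70000 nM.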

Compound 4, half-maximal inhibitory concentration: 9800 nM
The estimate for compound 4 lay 2.2-fold (0.35 log units) above the measured number; low and high end bracket the measured number.
By their numbers in this assay, from the lowest: compound 3; then compound 4; then compound 2.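

Exchanging pyridin-4-yl for 1-methyl-1H-pyrazol-5-yl on this aromatic carbon gives a 2.9-fold lower number from compound 2 to compound 4 (0.47 log units; beyond the scatter) in this assay. Among the compounds shown here, the number at this position therefore depends on the heteroaryl group, which no earlier matched pair could show. Nothing at hand explains the step.

The compounds shown cannot separate the contribution of the five-membered ring from that of its methyl group. Also open, as far as these compounds go, is how an unmethylated pyrazole, a plain phenyl ring or a morpholine would read at this carbon.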